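Sulfonyl aryl substituent swap within the shared core series

The source may report more compounds than this note shows. Statements on the series, on what has been measured and on what is new or still open speak of the compounds shown alone.

The series shares one core carrying an arylsulfonyl group whose substituent varies. Compound 1 `COc1ccc(-c2cc(=O)c3c(OC)cc(OC)cc3n2S(=O)(=O)c2ccc(C=O)cc2)cc1` bears a formyl group; in an ADME assay on BJ cells (Homo sapiens) for antiproliferative activity, with a stated time of 72 h (a higher number here means that more compound is needed for the effect, a lower number that less compound is needed), compound 1 gives only a limit, > 34400 nM. Compound 2 `COc1ccc(-c2cc(=O)c3c(OC)cc(OC)cc3n2S(=O)(=O)c2ccc(C#N)cc2)cc1` carries a nitrile; in this assay compound 2 likewise gives only a limit, > 17200 nM. Compound 3 `COc1ccc(-c2cc(=O)c3c(OC)cc(OC)cc3n2S(=O)(=O)c2ccc(C)cc2)cc1` carries a methyl; in this assay compound 3 also gives only a limit, > 44800 nM. Compound 3 therefore stands where the other two stand: at a limit, with no number to rank it against them. The steps between the measured compounds cannot be read: a step that the two limits leave unreadable from compound 1 to compound 2, a step that the two limits leave unreadable from compound 1 to compound 3 and a step that the two limits leave unreadable from compound 2 to compound 3 all remain unreadable because of the limit of > 17200 nM in this assay, at which 1 of the 3 values shown sits, the limit of > 34400 nM in this assay, at which 1 of the 3 values shown sits, and (the limit of > 44800 nM in this assay, at which 1 of the 3 values shown sits).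

Compound 4 `COc1ccc(-c2cc(=O)c3c(OC)cc(OC)cc3n2S(=O)(=O)c2ccc(OC)cc2)cc1` differs from compound 3 by methoxy in place of methyl on an aromatic carbon. Going by the values given here, no measured step bears on this change beyond showing that formyl, cyano and methyl all leave the value at a limit. The step of an at least 1.1-fold lower number from compound 3 to compound 4 (0.04 log units; that floor lies within the scatter) is expected to stay within the scatter. Compound 4 is expected to sit at a limit as well in this assay. The estimate for compound 4 in this assay is 40000 nM, between 15000 nM and 120000 nM.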

Compound 4, half-maximal effective concentration: > 82700 nM
Compound 4 ended at the assay's limit; the forecaster's own chance of this, stated with the estimate: 85%; middle value at least 2.0-fold (0.31 log units) from the limit.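

Going by these compounds alone, compound 4 also gives only a limit in this assay, > 82700 nM, so no step from compound 1, compound 2 or compound 3 to compound 4 can be read. The compounds shown leave open whether any substituent at this place on the arylsulfonyl group gives a readable number.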